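Adding methoxycarbonyl to the side chain of compound 2

The source may hold more compounds than are shown below. What is called first, only, known or untested is meant among the compounds shown, and "the series" means these compounds.

In a functional assay on HepG2 cells (Homo sapiens) for inhibition, read by crystal violet staining, with a stated time of 48 h (on this read-out higher numbers stand for weaker inhibition and lower numbers for stronger inhibition), compound 1 (`COC(=O)CCn1sc(Cl)cc1=O`) gives 24000 nM and compound 2 (`CCn1sc(Cl)c(Cl)c1=O`) gives 12000 nM so that compound 2 stands within the usual scatter of compound 1 and no order can be read between them. Compound 3 (`COC(=O)CCn1sc(Cl)c(Cl)c1=O`) differs from compound 2 by a single change (methoxycarbonyl in place of hydrogen on a saturated chain carbon, two bonds along the chain from an aromatic nitrogen) that places methoxycarbonyl in place of hydrogen on a saturated chain carbon, two bonds along the chain from an aromatic nitrogen. For the measured compounds named here, no pair of measured compounds isolates this change, so the data give no direct guide to its size. In this assay no shift beyond the scatter is expected, in either direction. The expected step of no change at the digits printed from compound 2 to compound 3 (within the scatter) is therefore estimated to stay within the scatter. For compound 3 the estimate is 12000 nM (expected range 5000 nM to 28000 nM).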

Compound 3, half-maximal inhibitory concentration: 16000 nM
Beside the measured number, compound 3's estimate is 1.3-fold (0.12 log units) below it; the measured number falls inside the stated range.
By their numbers in this assay, from the lowest: compounds 2, 3 and 1 (each within the scatter of the next).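

In this assay, methoxycarbonyl in place of hydrogen on a saturated chain carbon, two bonds along the chain from an aromatic nitrogen, gives a 1.3-fold higher number from compound 2 to compound 3 (0.12 log units; within the scatter) and thus no shift that can be told from the scatter at this position. The same holds for the second change now isolated: with methoxycarbonyl on the chain, chloro in place of hydrogen on an aromatic carbon gives a 1.5-fold lower number from compound 1 to compound 3 (0.18 log units; within the scatter) and so leaves no order to read between these compounds. No measured evidence bears on why either change has so small a step.

As far as these compounds go, it remains open whether a carboxylic acid or an amine on this chain carbon, or a longer chain, would give a step beyond the scatter. The compounds shown also leave open whether bromo or methyl on the aromatic carbon would do so.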